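The source may report more compounds than this note shows. Statements on the series, on what has been measured and on what is new or still open speak of the compounds shown alone.

Of the compounds shown here, three sharing one core have been tested in an ADME assay on SK-OV-3 cells (Homo sapiens) for cytotoxicity, read by sulforhodamine B assay, with a stated time of 48 h, tested at 10 uM; a higher number here means more inhibition at the concentration tested (going by the name of the read-out), a lower number less inhibition. Compound 1 `COc1nc2ccc(Br)cc2cc1C(c1ccccc1)n1cc(CCCO)nn1` gives 13.8%, compound 2 `COc1nc2ccc(Br)cc2cc1C(c1ccccc1)n1cc(-c2ccc(F)cc2)nn1` gives 14.3%, and compound 3 `COc1nc2ccc(Br)cc2cc1C(c1ccccc1)n1cc(CCCCCO)nn1` gives 8.69%. Compound 3 has the smallest of the three numbers, yet both other values lie within the usual scatter of it: the step of a number 5.1 percentage points lower from compound 1 to compound 3 (within the scatter) and the step of a number 5.6 percentage points lower from compound 2 to compound 3 (within the scatter) are both too small to count, as is the step of a number 0.5 percentage points higher from compound 1 to compound 2 (within the scatter). So far, swapping the group on the triazole ring between a hydroxyalkyl chain and a fluorinated aryl ring has left the read-out flat at a low level.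

Compound 4 `COc1nc2ccc(Br)cc2cc1C(c1ccccc1)n1cc(C2CC2)nn1` is the next member. Relative to compound 3 it carries a change (cyclopropyl in place of 5-hydroxypentyl on an aromatic carbon). Among the compounds with values here, the steps that bear on it are a number 5.6 percentage points lower from compound 2 to compound 3 (within the scatter) and a number 5.1 percentage points lower from compound 1 to compound 3 (within the scatter), both within the scatter, so no step beyond the scatter is expected in this assay. Compound 4 is therefore estimated at 11%, within 0% to 24%, an expected step of a number 2.3 percentage points higher from compound 3 to compound 4 (within the scatter).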

Compound 4, a percentage reported as inhibition, at one concentration (the size of the read-out at that concentration, not a potency): 3.52%
Beside the measured number, compound 4's estimate is 7.5 percentage points above it; the range from low to high includes it.
By their numbers in this assay, from the lowest: compounds 4, 3, 1 and 2 (each within the scatter of the next, the first and the last beyond it).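

Within the data shown here, this position can move the read-out after all: with cyclopropyl on the aromatic carbon of the five-membered ring, this assay shows a number 10.8 percentage points lower from compound 2 to compound 4 (beyond the scatter) and a number 10.3 percentage points lower from compound 1 to compound 4 (beyond the scatter), the first steps here to clear the scatter, though both are modest. The third step, a number 5.2 percentage points lower from compound 3 to compound 4 (within the scatter), does not clear it, so cyclopropyl cannot be told apart from 5-hydroxypentyl, even though only the chain brings a hydrogen-bond donor and acceptor. Nothing available explains why the number falls with this change.

Going by these compounds, it remains open whether a cyclobutyl or cyclohexyl ring at this carbon would read like cyclopropyl. A chain ending in an amine or a carboxylic acid could also shift the number in either direction, and the compounds shown cannot predict which.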